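From 3-hydroxypiperidin-1-yl to 4-hydroxypiperidin-1-yl

This account rests on a few compounds, and the source may have more. Where it says the series, first, only, none or still open, it means among the compounds named here.

- Compound 1 `O=S(=O)(c1ccccc1)c1nc2ccccc2nc1N1CCCC1` gives 35800 nM
- Compound 2 `O=S(=O)(c1ccccc1)c1nc2ccccc2nc1N1CCCC(O)C1` gives 3590 nM
- Compound 3 `Cc1ccc(S(=O)(=O)c2nc3ccccc3nc2N2CCCC(O)C2)cc1` gives 6080 nM

These values come from a functional assay on KB cells (Homo sapiens) for cytotoxicity, read by MTT assay, with a stated time of 72 h; a higher number here means a weaker inhibitor, a lower number a stronger inhibitor. Compound 2 stands at the low end of the three numbers, but it cannot be told apart from compound 3 , and only compound 1 lies clearly apart from it.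

Compound 4 `O=S(=O)(c1ccccc1)c1nc2ccccc2nc1N1CCC(O)CC1` has 4-hydroxypiperidin-1-yl in place of 3-hydroxypiperidin-1-yl on an aromatic carbon. The two compounds have the same atoms, joined differently.

Two measured steps offer some guidance. Exchanging pyrrolidin-1-yl for 3-hydroxypiperidin-1-yl gave a 10-fold lower number from compound 1 to compound 2 (1.00 log units; beyond the scatter), so a change in this group can matter. That exchange, however, replaced one group with a quite different one. Placing a methyl on an aromatic carbon elsewhere in the molecule gave a 1.7-fold higher number from compound 2 to compound 3 (0.23 log units; within the scatter). For the measured compounds named here, no measured pair shows the effect of moving the hydroxyl alone, so neither direction is well supported and no shift beyond the scatter is expected in this assay. The expected change is a 1.4-fold higher number from compound 2 to compound 4 (0.14 log units; within the scatter). Compound 4 is estimated at 5000 nM, with an expected range from 1500 nM to 15000 nM.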

Compound 4, half-maximal inhibitory concentration: 5360 nM
Beside the measured number, compound 4's estimate is 1.1-fold (0.03 log units) below it; the range from low to high includes it.
By their numbers in this assay, from the lowest: compounds 2, 4 and 3 (each within the scatter of the next); then compound 1.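

In this assay, moving the hydroxyl around the six-membered ring gives a 1.5-fold higher number from compound 2 to compound 4 (0.17 log units; within the scatter), so 3-hydroxypiperidin-1-yl and 4-hydroxypiperidin-1-yl cannot be told apart at this position on the shared core. Exchanging pyrrolidin-1-yl for 4-hydroxypiperidin-1-yl gives a 6.7-fold lower number from compound 1 to compound 4 (0.82 log units; beyond the scatter), so the step away from compound 1 is now seen with both placements of the hydroxyl and does not depend on the 3-hydroxypiperidin-1-yl group alone. Nothing in the available data explains these results.

The compounds shown still change two things at once when pyrrolidin-1-yl is replaced, the ring size and the hydroxyl, so they leave open which of the two goes with the lower numbers; a plain piperidin-1-yl group, with no hydroxyl, and a 3-hydroxypyrrolidin-1-yl group would pull these two changes apart. They also leave open whether the hydroxyl itself matters on the six-membered ring, a question that a 4-methoxypiperidin-1-yl or a 4-aminopiperidin-1-yl group at the same position could address.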